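This account rests on a few compounds, and the source may have more. Where it says the series, first, only, none or still open, it means among the compounds named here.

Three compounds have numbers in a functional assay on OVCAR-8 cells (Homo sapiens) for inhibition, read by sulforhodamine B assay, with a stated time of 48 h, tested at 10 uM; on this read-out lower numbers stand for less inhibition and higher numbers for more inhibition at the one concentration tested (going by the name of the read-out):

Compound 1, `c1ccc(-c2cn3ccnc3c(-c3ccc4ncn(C5CCCCC5)c4c3)n2)cc1`: 63.9%
Compound 2, `Fc1ccc(-c2cn3ccnc3c(-c3ccc4ncn(C5CCCCC5)c4c3)n2)cc1`: 9.54%
Compound 3, `Brc1ccc(-c2cn3ccnc3c(-c3ccc4ncn(C5CCCCC5)c4c3)n2)cc1`: 13.2%

Compound 3 stands second highest of the three. Its nearest neighbour is compound 2, with a number 3.7 percentage points higher from compound 2 to compound 3 (within the scatter), so the two show no order between them. Its furthest is compound 1, with a number 50.7 percentage points lower from compound 1 to compound 3 (beyond the scatter).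

Compound 4, `c1csc(-c2cn3ccnc3c(-c3ccc4ncn(C5CCCCC5)c4c3)n2)c1`, is not yet measured in this assay. It differs from compound 3 by thiophen-2-yl in place of 4-bromophenyl on an aromatic carbon, on an aromatic carbon of a six-membered aromatic ring with 2 nitrogen, part of a fused or bridged system of two rings.

Among the compounds with values here, no measured step swaps the phenyl ring itself for another ring, so the evidence is indirect. The two large steps, a number 54.4 percentage points lower from compound 1 to compound 2 (beyond the scatter) and a number 50.7 percentage points lower from compound 1 to compound 3 (beyond the scatter), both put a halogen onto hydrogen at this position and both pull the number far down, while a number 3.7 percentage points higher from compound 2 to compound 3 (within the scatter) shows the two halogens alike. Compound 4 carries no halogen on the entering ring, which points back toward the higher number of compound 1, though the ring itself is new.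

Compound 4 is therefore expected to give about 40%, with a range from 10% to 70%. The expected step is a number 26.8 percentage points higher from compound 3 to compound 4 (beyond the scatter), upward and beyond the scatter, with wide uncertainty.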

Compound 4, a percentage reported as inhibition, at one concentration (the size of the read-out at that concentration, not a potency): 9.34%
Compound 4: middle estimate off by 30.7 percentage points, on the high side; measured number outside the range, below it.
By their numbers in this assay, from the lowest: compounds 4, 2 and 3 (each within the scatter of the next); then compound 1.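

In this assay, the result shows that the absence of a halogen on the entering ring is not enough to keep the high number of compound 1: the thiophen-2-yl ring carries no halogen, yet the change gives a large drop (a number 54.6 percentage points lower from compound 1 to compound 4 (beyond the scatter)), alongside the large drops for fluoro (a number 54.4 percentage points lower from compound 1 to compound 2 (beyond the scatter)) and bromo (a number 50.7 percentage points lower from compound 1 to compound 3 (beyond the scatter)). Compound 4 shows no order against either halogen compound (a number 3.9 percentage points lower from compound 3 to compound 4 (within the scatter); a number 0.2 percentage points lower from compound 2 to compound 4 (within the scatter)), so among these four compounds only the phenyl group of compound 1 stands apart, and both the ring swap and the two halogens go with the low level. No measurement offered here explains why these three different changes end at the same level.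

The compounds shown leave open whether this level extends to a methyl, methoxy or amine group on the phenyl ring, or whether it is specific to halogens among such groups. They also leave open how a pyridine ring or thiophen-3-yl would read at this position on the shared core.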